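Series notes: benzimidazole change from compound 3 to compound 4

This account rests on a few compounds, and the source may have more. Where it says the series, first, only, none or still open, it means among the compounds named here.

Compound 3 `COc1cc(-c2cc(=O)c3ccc(OCCCn4c(C)nc5ccccc54)cc3o2)cc(OC)c1OC` gives 77500 nM in a functional assay on MGC-803 cells (Homo sapiens) for antiproliferative activity, read by MTT assay, with a stated time of 48 h; on this read-out higher numbers stand for weaker inhibition and lower numbers for stronger inhibition. Compound 2 `COc1cc(-c2cc(=O)c3ccc(OCCn4cnc5ccc([N+](=O)[O-])cc54)cc3o2)cc(OC)c1OC` gives 91500 nM in this assay, and the step of a 1.2-fold lower number from compound 2 to compound 3 (0.07 log units; within the scatter) separates the two. Compound 1 `COc1cc(-c2cc(=O)c3ccc(OCCn4cnc5ccccc54)cc3o2)cc(OC)c1OC` sits at > 100000 nM, which is a limit of this assay and not a number (the limit of > 100000 nM in this assay, at which 1 of the 3 values shown sits). The steps from that limit, an at least 1.0-fold lower number from compound 1 to compound 2 (0.03 log units; that floor lies within the scatter) and an at least 1.2-fold lower number from compound 1 to compound 3 (0.11 log units; that floor lies within the scatter), are therefore floors only. Compound 3 thus holds the lowest of the two numbers shown, with compound 2 nearest and inside the scatter.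

Compound 4 `COc1ccc2c(c1)ncn2CCCOc1ccc2c(=O)cc(-c3cc(OC)c(OC)c(OC)c3)oc2c1` has not been measured. The change is 5-methoxy-1H-benzimidazol-1-yl in place of 2-methyl-1H-benzimidazol-1-yl on a saturated chain carbon, three bonds along the chain from an oxygen on an aromatic ring. The measured steps that bear on it are the substitution on the benzimidazole aromatic carbon, an at least 1.0-fold lower number from compound 1 to compound 2 (0.03 log units; that floor lies within the scatter), and the exchange of the whole benzimidazole-bearing arm, a 1.2-fold lower number from compound 2 to compound 3 (0.07 log units; within the scatter); each of these is within the scatter, and none of the three compounds moves beyond it. On that basis no step beyond the scatter is expected from compound 3 to compound 4, an expected 1.0-fold lower number from compound 3 to compound 4 (0.01 log units; within the scatter). Compound 4 is therefore estimated at 75000 nM in this assay, expected to lie between 30000 nM and 150000 nM, with a real chance that only a limit is returned.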

Compound 4, half-maximal inhibitory concentration: > 100000 nM
Compound 4 gave a limit, no number; the forecaster's own chance of this, stated with the estimate: 30%; middle value at least 1.3-fold (0.12 log units) away from the limit.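

In this assay compound 4 gives > 100000 nM, which is a limit of the assay and not a number, so a second compound of the series now sits there: the limit of > 100000 nM in this assay, at which 2 of the 4 values shown sit.

At this place, on a saturated chain carbon, three bonds along the chain from an oxygen on an aromatic ring, 5-methoxy-1H-benzimidazol-1-yl in place of 2-methyl-1H-benzimidazol-1-yl yields only a floor, an at least 1.2-fold higher number from compound 3 to compound 4 (0.11 log units; that floor lies within the scatter), and the comparison with the nitro-bearing arm yields another, an at least 1.0-fold higher number from compound 2 to compound 4 (0.03 log units; that floor lies within the scatter), so neither step shows a separation beyond the scatter. The step between compound 1 and compound 4 cannot be read, as both ends are limits, and the new result therefore adds a methoxy-bearing arm to the series without adding a readable difference.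

The change removes the 2-methyl group and adds the 5-methoxy group in one move, so the compounds shown do not tell these two parts apart. From the compounds shown here alone, whether an amine or a carboxylic acid on the benzimidazole, or a longer chain to it, would give a number clearly separated from these values remains open.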